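Amine side chain change from compound 2 to compound 3

A few compounds are considered here, and "the series" means these few. Any claim that something is new, unique, unknown or untested is made for them only; others in the source may bear on it.

In a functional assay on the whole organism with Rattus norvegicus as the target (on this read-out lower numbers stand for an effect already at smaller amounts and higher numbers for an effect only at larger amounts of compound), compound 1 `N=c1sc2cc(OC(F)(F)F)ccc2n1CCS(=O)(=O)O` gives > 10 mg/kg, which is a limit of the assay and not a number. Compound 2 `CNCCn1c(=N)sc2cc(OC(F)(F)F)ccc21` gives > 10 mg/kg, which is also a limit. Compound 2 therefore sits with compound 1 at the limit of > 10 mg/kg in this assay, at which 2 of the 2 values shown sit, and the series has no numerical value yet.

The next structure is compound 3 `CN(C)CCCn1c(=N)sc2cc(OC(F)(F)F)ccc21`, and the change is (dimethylamino)methyl in place of methylamino on a saturated chain carbon, two bonds along the chain from an aromatic nitrogen. Going by the values given here, the only measured step at this place on the chain is a step that the two limits leave unreadable from compound 1 to compound 2, which offers neither a size nor a direction to carry forward. No step beyond the scatter is therefore expected in this assay, and the estimated step that the limit leaves unreadable from compound 2 to compound 3 remains a weak working figure. A further limit is the likeliest report. For compound 3 the expected value is 14 mg/kg, with an estimated range of 5 mg/kg to 40 mg/kg.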

Compound 3, dose for half-maximal effect: 9 mg/kg
Estimate against measurement, compound 3: 1.6-fold (0.19 log units) above; low and high end bracket the measured number.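

In this assay, compound 3 gives the series its first number, so this saturated chain carbon, two bonds along the chain from an aromatic nitrogen, no longer carries only limits: the limit of > 10 mg/kg in this assay, at which 2 of the 3 values shown sit.

Placing (dimethylamino)methyl there in place of methylamino gives an at least 1.1-fold lower number from compound 2 to compound 3 (0.04 log units; that floor lies within the scatter), and placing it there in place of sulfo gives an at least 1.1-fold lower number from compound 1 to compound 3 (0.04 log units; that floor lies within the scatter). From the compounds shown here alone, both steps are floors set by limits, so their true size is unknown and the floors alone establish no gain.

The change from 2-(methylamino)ethyl to 3-(dimethylamino)propyl combines a longer chain with the dimethylamino group, and the compounds shown do not separate the two. Also open, going by these compounds, is how 3-(methylamino)propyl, 2-(dimethylamino)ethyl or a piperidine in place of the dimethylamino group would read in this assay.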